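The compounds below may be only part of what the source reports. "The series", "measured", "known", "first", "only" and "open" are said of these compounds alone.

Going by the values given here, compound 2 `COc1ccc(/C=N/NC(=O)Nc2ccc(Oc3ccnc(-c4nncn4CCN(C)C)c3)c(F)c2)c(OC)c1` stands highest of the two numbers so far in a functional assay on MKN-45 cells (Homo sapiens) for cytotoxicity, read by MTT assay, with a stated time of 72 h (a lower number here means a stronger inhibitor, a higher number a weaker inhibitor), where compound 2 gives 1680 nM. Its nearest neighbour, compound 1 `CN(C)CCn1cnnc1-c1cc(Oc2ccc(NC(=O)N/N=C/c3ccc(Cl)cc3Cl)cc2F)ccn1`, gives 750 nM in this assay, and the change a 2.2-fold higher number from compound 1 to compound 2 (0.35 log units; beyond the scatter) touched the same position. Compound 3 `CN(C)CCn1cnnc1-c1cc(Oc2ccc(NC(=O)N/N=C/c3ccc(O)c(O)c3)cc2F)ccn1` differs from compound 2 by 3,4-dihydroxyphenyl in place of 2,4-dimethoxyphenyl on a carbon with a double bond to nitrogen. Among the compounds with values here, only that one step bears on this change, and it was modest, so compound 3 is expected to move by about a 1.2-fold lower number from compound 2 to compound 3 (0.08 log units; within the scatter) in this assay, a step not clearly beyond the scatter. Compound 3 is therefore estimated at 1400 nM, within 600 nM to 3500 nM.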

Compound 3, half-maximal inhibitory concentration: 3240 nM
Compound 3: the middle estimate sits 2.3-fold (0.36 log units) below what was measured, within the range that was stated.
By their numbers in this assay, from the lowest: compound 1; then compounds 2 and 3 (each within the scatter of the next).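

In this assay, the change to 3,4-dihydroxyphenyl gives a 1.9-fold higher number from compound 2 to compound 3 (0.29 log units; within the scatter), so adding hydrogen-bond donors on this ring does not separate compound 3 from compound 2. Set against 2,4-dichlorophenyl, the same group gives a 4.3-fold higher number from compound 1 to compound 3 (0.64 log units; beyond the scatter), leaving compound 1 the strongest of the three. Nothing measured here explains these differences. Open, as far as these compounds go, is where an unsubstituted phenyl or a phenyl carrying an amine would fall. Also open, from the compounds shown here alone, is whether the chlorine atoms or their placement matter more, as compound 3 changes both the groups and their placement.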